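Matched thiophene swap on two related fused cores

This account rests on a few compounds, and the source may have more. Where it says the series, first, only, none or still open, it means among the compounds named here.

Measured so far:
compound 1 `Cc1cc(-c2nc3sc(C)cn3c2/C=N/NC(=N)N)c(C)s1` — 8320 nM
compound 2 `Cc1cn2c(/C=N/NC(=N)N)c(-c3ccsc3)nc2s1` — 6920 nM
compound 3 `N=C(N)N/N=C/c1c(-c2ccsc2)nc2n1CCS2` — 25100 nM

Of the compounds shown here, three have been tested in a functional assay on cells (Cancer cell lines, Homo sapiens) for inhibition; on this read-out lower numbers stand for stronger inhibition of growth and higher numbers for weaker inhibition of growth. Compound 2 `Cc1cn2c(/C=N/NC(=N)N)c(-c3ccsc3)nc2s1` gives 6920 nM, and compound 1 `Cc1cc(-c2nc3sc(C)cn3c2/C=N/NC(=N)N)c(C)s1` gives 8320 nM. The two share a core and differ in one place: 2,5-dimethylthiophen-3-yl in place of thiophen-3-yl on an aromatic carbon. That step, a 1.2-fold higher number from compound 2 to compound 1 (0.08 log units; within the scatter), is small enough to count as no real change.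

Compound 3 `N=C(N)N/N=C/c1c(-c2ccsc2)nc2n1CCS2` sits on a different core and gives 25100 nM in this assay, the highest of the three numbers; the difference between its core and that of compound 2 is not broken down here.

Compound 4 `Cc1cc(-c2nc3n(c2/C=N/NC(=N)N)CCS3)c(C)s1` has not yet been measured. It differs from compound 3 by 2,5-dimethylthiophen-3-yl in place of thiophen-3-yl on an aromatic carbon. Among the measured compounds shown here, this is the same kind of change as the one from compound 2 to compound 1, not the same: the place is described as two ring bonds from two ring atoms that each bear a fused ring, which was not part of the earlier description. For compound 4 the expected step is a 1.1-fold higher number from compound 3 to compound 4 (0.05 log units; within the scatter) in this assay, beside the earlier one, because the matched step a 1.2-fold higher number from compound 2 to compound 1 (0.08 log units; within the scatter) stayed within the scatter. Compound 4 is therefore expected to give about 28000 nM, with a likely range from 12000 nM to 65000 nM.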

Compound 4, concentration for 50% growth inhibition: 18600 nM
Beside the measured number, compound 4's estimate is 1.5-fold (0.18 log units) above it; the range from low to high includes it.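

In this assay, placing 2,5-dimethylthiophen-3-yl where thiophen-3-yl stood on the second core gives a 1.3-fold lower number from compound 3 to compound 4 (0.13 log units; within the scatter), so on this core too the swap produces no real change in growth inhibition. The two matched steps can then be compared directly, and they agree: the same change on two cores in this assay, a 1.2-fold higher number (0.08 log units; within the scatter) from compound 2 to compound 1 and a 1.3-fold lower number (0.13 log units; within the scatter) from compound 3 to compound 4, 1.6-fold (0.21 log units) apart, within the scatter of two such steps. Among the compounds shown here, this shows that, across these two cores, the swap carried over as no real change, but it does not show that it would do so on a third core, and with only two pairs and both steps inside the scatter, a small real effect cannot be told apart from ordinary variation between repeated measurements.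

Both pairs test only thiophen-3-yl against its 2,5-dimethyl version, so the compounds shown say nothing about how a different group in this place, such as an amine, a carboxylic acid or a longer chain, would behave on either core. It also remains open what sets the two cores apart, since they differ by more than this one swap and the compounds shown do not separate that difference into single changes.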